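Nitro for Methyl on a Shared Benzothiazole Amide Core

The source may report more compounds than this note shows. Statements on the series, on what has been measured and on what is new or still open speak of the compounds shown alone.

Of the compounds shown here, three with a shared core have been tested in a functional assay on SK-HEP1 cells (Homo sapiens) for antiproliferative activity, read by sulforhodamine B assay; a lower number here means a stronger inhibitor of growth, a higher number a weaker inhibitor of growth. For the measured compounds named here, compound 1, `Cc1ccc(C(=O)Nc2nc3cc(C)cc(C)c3s2)cc1`, is the only one that gives a number: in this assay compound 1 gives 2.17 ug/mL. Compound 2, `O=C(Nc1ccccc1)Nc1nc2ccc(F)cc2s1`, gives > 10 ug/mL in this assay, which is a limit of the assay rather than a number. Compound 3, `COc1ccc2sc(NC(=O)c3ccc([N+](=O)[O-])cc3)nc2c1`, likewise gives > 10 ug/mL in this assay, again a limit. So compound 1 stands alone with a measured value, while the other two sit at the limit of > 10 ug/mL in this assay, at which 2 of the 3 values shown sit.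

The next compound, compound 4, `Cc1cc(C)c2sc(NC(=O)c3ccc([N+](=O)[O-])cc3)nc2c1`, is compound 1 with one change: nitro in place of methyl on an aromatic carbon. Going by the values given here, no step between two measured compounds shows directly what this change does. Compound 3, which carries the same nitro group on a different core, sits at the limit, whereas compound 1 with its methyl gives a number, so the change is expected to weaken growth inhibition by more than the usual scatter. The step from compound 1 to compound 4 is therefore estimated as a 2.8-fold higher number from compound 1 to compound 4 (0.44 log units; beyond the scatter). In this assay compound 4 is expected to give about 6 ug/mL, with a likely range from 2.5 ug/mL to 15 ug/mL.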

Compound 4, concentration for 50% growth inhibition: 1.74 ug/mL
The estimate for compound 4 lay 3.4-fold (0.54 log units) above the measured number, and the stated range ends above it.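

For the compounds shown here, the first direct reading of this change comes from the pair compound 1 and compound 4: in this assay, nitro in place of methyl gives a 1.2-fold lower number from compound 1 to compound 4 (0.10 log units; within the scatter). The two compounds therefore cannot be told apart in this assay, even though the position, on a six-membered aromatic ring of carbon only and para to a large group, goes from holding 1 heavy atom and 0 hydrogen-bond acceptors to holding 3 heavy atoms and 2 hydrogen-bond acceptors. On the core of compound 1, then, this position accepts either group with growth inhibition kept within the usual scatter, while the steps from compound 1 to compound 2 and compound 3 cannot be read because those values are limits of the assay and the compounds differ in more than one place: the limit of > 10 ug/mL in this assay, at which 2 of the 4 values shown sit.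

Going by these compounds, what remains open is whether this tolerance extends to groups of another kind at the same position, such as an amine, a carboxylic acid or a longer chain. Going by these compounds alone, the pair also cannot tell whether nitro and methyl would again match on a different core, since this one step is the only direct reading of the change.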